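Hydrazone series: aryl for chain on compound 3

A few compounds are considered here, and "the series" means these few. Any claim that something is new, unique, unknown or untested is made for them only; others in the source may bear on it.

Among the compounds with values here, in an assay on CHO-K1 cells for displacement of a labelled ligand from adenosine receptor A1 (Homo sapiens), read by scintillation counting, with a stated time of 60 min (on this read-out higher numbers stand for weaker inhibition and lower numbers for stronger inhibition), compound 3 `CCCCC/C=C/C=C/C=N/Nc1nc(N)c2ncn([C@@H]3O[C@H](CO)[C@@H](O)[C@H]3O)c2n1` gives 2 nM, the lowest of the three numbers measured so far. Within the data shown here, compound 1 `Nc1nc(N/N=C/c2ccc3ncccc3c2)nc2c1ncn2[C@@H]1O[C@H](CO)[C@@H](O)[C@H]1O` gives 9.8 nM in this assay, and the exchange of its ring pair for the chain is the one single-point step in hand: a 4.9-fold lower number from compound 1 to compound 3 (0.69 log units; beyond the scatter). Among the measured compounds shown here, compound 2 `Nc1nc(N/N=C/c2ccc(-c3ccccn3)cc2)nc2c1ncn2[C@@H]1O[C@H](CO)[C@@H](O)[C@H]1O` gives 7540 nM; no single-point step connects it to compound 3, and the two values simply show a far wider gap than the one to compound 1.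

Compound 4 `CN(C)c1ccc(/C=N/Nc2nc(N)c3ncn([C@@H]4O[C@H](CO)[C@@H](O)[C@H]4O)c3n2)cc1` is not yet measured. Its difference from compound 3: a group of 9 heavy atoms (8 carbon, 1 nitrogen; one six-membered aromatic ring of carbon only) in place of a group of 9 heavy atoms (9 carbon; no ring), on a carbon with a double bond to nitrogen. The step of a 4.9-fold lower number from compound 1 to compound 3 (0.69 log units; beyond the scatter) bears on this, since it ran from an aromatic group to the chain on the same carbon and lowered the number modestly; the present change goes back from the chain to an aromatic group, here the 4-(dimethylamino)phenyl group. Compound 1 shows an aromatic group staying close to compound 3, whereas compound 2 shows one much further away. A rise beyond the scatter is therefore expected, of uncertain size. Compound 4 is estimated at 80 nM, within 8 nM to 800 nM, the expected step being a 40-fold higher number from compound 3 to compound 4 (1.60 log units; beyond the scatter).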

Compound 4, inhibition constant: > 10000 nM
Compound 4: only a limit was reported (the forecaster's own chance of this, stated with the estimate: 2%); at least 120-fold (2.09 log units) between middle value and limit.
By their numbers in this assay, from the lowest: compound 3; then compound 1; then compound 2. At a limit, above all of these: compound 4.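

In this assay compound 4 gives > 10000 nM, which is a limit and not a number. The exchange of the chain for 4-(dimethylamino)phenyl on the carbon with a double bond to nitrogen gives an at least 5000-fold higher number from compound 3 to compound 4 (3.69 log units; beyond the scatter) as its step. The exchange of quinolin-6-yl for 4-(dimethylamino)phenyl at this place gives an at least 1000-fold higher number from compound 1 to compound 4 (3.00 log units; beyond the scatter) as its step, so the low number of compound 1 does not carry over to every aromatic group at this place. The exchange of pyridin-2-yl for dimethylamino on an aromatic carbon gives an at least 1.3-fold higher number from compound 2 to compound 4 (0.12 log units; that floor lies within the scatter) and cannot be read, so compound 4 adds a second aromatic group with a high number at this place but cannot be ranked against compound 2.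

As far as these compounds go, how far compound 4 lies past the limit stays unknown, and with it the true size of both readable steps: the limit of > 10000 nM in this assay, at which 1 of the 4 values shown sits. Whether the dimethylamino group or the phenyl ring underlies the change also stays open, and an unsubstituted phenyl, a 4-methoxyphenyl or a saturated hexyl chain on this carbon would help to separate these.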